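Replacing the azide of compound 2 with an amine

The compounds below may be only part of what the source reports. "The series", "measured", "known", "first", "only" and "open" are said of these compounds alone.

Compound 1: `OCc1cc2ccccc2nc1-c1ccccc1O` — > 100000 nM
Compound 2: `[N-]=[N+]=NCc1cc2ccccc2nc1-c1ccccc1O` — 12000 nM
Compound 3: `NCc1cc2ccccc2nc1-c1ccccc1O` — not yet measured

Of the compounds shown here, two sharing one core have been tested in a functional assay on MDA-MB-231 cells (Homo sapiens) for cytotoxicity, read by MTT assay, with a stated time of 24 h; a higher number here means a weaker inhibitor, a lower number a stronger inhibitor. For compound 1 the result is only a limit, > 100000 nM. For the measured compounds named here, compound 2 gives 12000 nM, the only actual number so far, so it stands alone among the measured values. Going by the values given here, the one step available, an at least 8.3-fold lower number from compound 1 to compound 2 (0.92 log units; beyond the scatter), shows that the azide brought the compound down from the limit to a measurable number.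

Compound 3 takes the change (amino in place of azido on a saturated chain carbon bound to an aromatic carbon). This removes the very group that distinguished compound 2 from compound 1, and it brings back a hydrogen-bond donor on the same chain carbon. The step from compound 1 to compound 2 is the only one that bears on this change, and it points toward the azide being needed for the measured number; without it, a weaker result is expected. Compound 3 is therefore estimated at 40000 nM, in the range 8000 nM to 200000 nM, meaning an expected step of a 3.3-fold higher number from compound 2 to compound 3 (0.52 log units; beyond the scatter).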

Compound 3, half-maximal inhibitory concentration: 19000 nM
The estimate for compound 3 lay 2.1-fold (0.32 log units) above the measured number; the measured number falls inside the stated range.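

In this assay, putting amino in place of azido on this saturated chain carbon gives a 1.6-fold higher number from compound 2 to compound 3 (0.20 log units; within the scatter), so the two groups cannot be told apart in this test, and the azido group turns out not to be required for a measurable number. Amino in place of hydroxy at the same place gives an at least 5.2-fold lower number from compound 1 to compound 3 (0.72 log units; beyond the scatter), which means that azido is no longer the only group shown to separate from hydroxy here. On these data alone, the full size of that step remains unknown, since compound 1 gives only a limit and not a number: the limit of > 100000 nM in this assay, at which 1 of the 3 values shown sits.

What the compounds shown leave open is how far this tolerance at the chain carbon extends, for example whether a dimethylamino group, a carboxylic acid or a longer chain ending in an amine would keep a number in the same range as compound 2 and compound 3. They also leave open what part the hydroxy group shared by all three compounds on the core plays, as well as whether any group at this place could give a much lower number.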